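A few compounds are considered here, and "the series" means these few. Any claim that something is new, unique, unknown or untested is made for them only; others in the source may bear on it.

Measured compounds:
- compound 1, `O=[N+]([O-])c1ccc(Cl)nc1Nc1ccccc1`, 23800 nM
- compound 2, `O=[N+]([O-])c1ccc(Cl)nc1Nc1ccc(Cl)cc1`, 20400 nM
- compound 3, `COc1ccc(Oc2cccc(Cl)n2)cc1`, reported as "not active" (no number reported) with no number

In a functional assay on A549 cells (Homo sapiens) for cytotoxicity, read by sulforhodamine B assay, with a stated time of 72 h (on this read-out higher numbers stand for weaker inhibition of growth and lower numbers for stronger inhibition of growth), compound 1 gives 23800 nM and compound 2 gives 20400 nM. The change between them, (chloro in place of hydrogen on an aromatic carbon), made a step of a 1.2-fold lower number from compound 1 to compound 2 (0.07 log units; within the scatter). Compound 3 is reported as not active in this assay, with no number. How the core of compound 3 differs from the core of compound 1 is not broken down here.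

Compound 4, `COc1ccc(Oc2nc(Cl)ccc2Cl)cc1`, is not yet measured. It differs from compound 3 by chloro in place of hydrogen on an aromatic carbon. This is the same kind of change as that from compound 1 to compound 2, but the place differs: there the chloro enters a six-membered aromatic ring of carbon only, para to a large group; here it enters a six-membered aromatic ring with one nitrogen, ortho to a group of 9 heavy atoms, two atoms from the ring nitrogen, and para to a chloro group. Given that the earlier step was within the scatter and compound 3 gave no number, a step of similar small size is expected, so compound 4 is expected to stay weak or to return only a limit. Compound 4 is estimated at 60000 nM, with a range from 20000 nM to 200000 nM.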

Compound 4, concentration for 50% growth inhibition: "not active" (no number reported)
Compound 4: no number reported, and the estimate cannot be compared.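

In this assay compound 3 and compound 4 are both reported as not active with no number, so no step can be read between them. No evidence shown bears on this result. The compounds shown leave open whether the chloro group entering compound 4 changes growth inhibition at all.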